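The compounds below may be only part of what the source reports. "The series", "measured", "known", "first", "only" and "open" are said of these compounds alone.

Measured in a functional assay on HOS cells (Homo sapiens) for antiproliferative activity, read by sulforhodamine B assay (a higher number here means a weaker inhibitor of growth, a lower number a stronger inhibitor of growth), so far:
- compound 1 `OCC[C@@H]1O[C@H](COCc2ccccc2)[C@@H](OCc2ccccc2)[C@H](OCc2ccccc2)[C@H]1O` gives 39700 nM as a number
- compound 2 `c1ccc(COC[C@H]2O[C@H]3C[C@H]3[C@@H](OCc3ccccc3)[C@@H]2OCc2ccccc2)cc1` gives > 50000 nM (a limit)
- compound 3 `C[C@@H]1O[C@H](COCc2ccccc2)[C@@H](OCc2ccccc2)[C@H](OCc2ccccc2)C1=O` gives > 50000 nM (a limit)

Compound 3 stands on a limit (> 50000 nM) and has no number in this assay. The common reading in this small set is a limit (the limit of > 50000 nM in this assay, at which 2 of the 3 values shown sit). Compound 1 alone returns a number (39700 nM).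

Compound 4 `CC(C)C[C@@H]1O[C@H](COCc2ccccc2)[C@@H](OCc2ccccc2)[C@H](OCc2ccccc2)C1=O` is still unmeasured. The change from compound 3 is isopropyl in place of hydrogen on a saturated chain carbon bound to a saturated ring carbon (isopropyl in place of hydrogen on a saturated chain carbon bound to a saturated ring carbon; the same difference reads methyl to isobutyl when cut one bond further out). Within the data shown here, no measured step in the set covers this change, so the expectation rests on little. In this assay a small step toward stronger growth inhibition is expected, and nothing larger than a modest one. Among the measured compounds shown here, the only number in the set, from compound 1 (39700 nM), points to an expected reading in the same region. The expected change is an at least 1.4-fold lower number from compound 3 to compound 4 (0.15 log units; that floor lies within the scatter) in size. Another report of compound 4 as a limit alone is also quite possible. For compound 4 the estimated value is 35000 nM with an expected range (12000 nM to 50000 nM).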

Compound 4, concentration for 50% growth inhibition: > 50000 nM
Compound 4: a limit, no number; the forecaster's own chance of this, stated with the estimate: 55%; at least 1.4-fold (0.15 log units) between middle value and limit.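

In this assay compound 4 gives > 50000 nM, a limit, and no step can be read between compound 3 and compound 4, as both stand on limits: the limit of > 50000 nM in this assay, at which 3 of the 4 values shown sit. The compounds shown leave open whether isopropyl in place of hydrogen on a saturated chain carbon bound to a saturated ring carbon changes growth inhibition at all.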